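From Cyclopropylmethyl to a Five-Membered Aromatic Ring

The compounds below may be only part of what the source reports. "The series", "measured", "known", "first", "only" and "open" are said of these compounds alone.

Three related acids share one core, and each differs only in the group on an oxygen on an aromatic ring. In a physicochemical assay for permeability, using PAMPA (on this read-out lower numbers stand for lower permeability and higher numbers for higher permeability), compound 1 `O=C(O)CCn1c(=O)oc2cc(OCc3ccccc3)c(Cl)cc21` offers no number, its entry reading "not determined" (no result reported). Compound 2 `O=C(O)CCn1c(=O)oc2cc(OCc3ccccn3)c(Cl)cc21` gives 11 nm/s, and compound 3 `O=C(O)CCn1c(=O)oc2cc(OCC3CC3)c(Cl)cc21` gives 19 nm/s. Among the measured compounds shown here, these are the only two numbers available, and they sit within the scatter of each other, so compound 3 cannot be ranked on them.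

The next compound, compound 4 `C[C@@H](Oc1cc2oc(=O)n(CCC(=O)O)c2cc1Cl)c1ncco1`, changes that group again: a group of 7 heavy atoms (5 carbon, 1 nitrogen, 1 oxygen; one five-membered aromatic ring with 2 hetero atoms) in place of a group of 4 heavy atoms (4 carbon; one three-membered non-aromatic ring of carbon only), on an oxygen on an aromatic ring. For the measured compounds named here, only one measured step bears on this change, namely a 1.7-fold higher number from compound 2 to compound 3 (0.24 log units; within the scatter). That step exchanged pyridin-2-yl for cyclopropyl on a saturated chain carbon bound to an oxygen on an aromatic ring, and it stayed within the scatter. The new change runs the other way, from a carbon-only three-membered ring to an aromatic ring. Going by the values given here, no measured compound has a five-membered aromatic ring with 2 hetero atoms or a defined stereocentre, so the evidence is thin and no shift beyond the scatter is expected in this assay. The expected step is a 1.5-fold lower number from compound 3 to compound 4 (0.16 log units; within the scatter). For compound 4 the estimated value is 13 nm/s, within an expected range of 6 nm/s to 28 nm/s.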

Compound 4, apparent permeability: < 3 nm/s
Compound 4: only a limit was reported; the forecaster's own chance of this, stated with the estimate: 5%; middle value at least 4.3-fold (0.63 log units) away from the limit.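

The reading for compound 4 in this assay is a limit and not a number: the limit of < 3 nm/s in this assay, at which 1 of the 4 values shown sits.

Even so, it shows that the group on this oxygen can move the read-out beyond the scatter, which the earlier pair did not show: exchanging cyclopropylmethyl for the new group gives an at least 6.3-fold lower number from compound 3 to compound 4 (0.80 log units; beyond the scatter), whereas the only earlier step, a 1.7-fold higher number from compound 2 to compound 3 (0.24 log units; within the scatter), stayed within it. The exchange from the pyridin-2-yl group gives an at least 3.6-fold lower number from compound 2 to compound 4 (0.56 log units; beyond the scatter), so the result holds whichever of these two groups is the starting point, and each step is a minimum size, not an exact one.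

The entering group brings a five-membered aromatic ring with 2 hetero atoms and a defined stereocentre in a single change, so these compounds cannot separate the two or show whether the opposite stereocentre would read the same. Steps involving compound 1 cannot be read, and how a chain ending in an amine or a plain ethyl group would read on this oxygen stays open.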